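A Methyl Group Enters the Ring of Compound 3

The source may report more compounds than this note shows. Statements on the series, on what has been measured and on what is new or still open speak of the compounds shown alone.

Compound 1 `CC1(C)Cc2c(sc(NC(=O)c3nnc[nH]3)c2C(N)=O)C(C)(C)O1`: 467 nM
Compound 2 `CC1(C)Cc2c(sc(NC(=O)c3cn[nH]c3)c2C(N)=O)C(C)(C)O1`: 125 nM
Compound 3 `CC1(C)Cc2c(sc(NC(=O)c3[nH]ncc3Cl)c2C(N)=O)C(C)(C)O1`: 2 nM

Of the compounds shown here, three with a shared core have been measured in an assay on cells for positive allosteric modulation of Cystic fibrosis transmembrane conductance regulator variant F508del (Homo sapiens), with stated times of 10 min and 7 s, in the presence of a further agent that is not named here; a lower number here means that less compound is needed, a higher number that more compound is needed for the effect. Compound 1 gives 467 nM, compound 2 gives 125 nM, and compound 3 gives 2 nM. Compound 3 stands lowest of the three numbers, with a gap to its nearest neighbour of a 63-fold lower number from compound 2 to compound 3 (1.80 log units; beyond the scatter) and a gap to the furthest of a 230-fold lower number from compound 1 to compound 3 (2.37 log units; beyond the scatter); the remaining step, a 3.7-fold lower number from compound 1 to compound 2 (0.57 log units; beyond the scatter), is modest. All three steps exchange one five-membered aromatic ring for another on the carbonyl carbon.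

Compound 4 `Cc1n[nH]c(C(=O)Nc2sc3c(c2C(N)=O)CC(C)(C)OC3(C)C)c1Cl` differs from compound 3 by methyl in place of hydrogen on an aromatic carbon. Within the data shown here, none of the measured steps bears directly on this change: each of them swapped the whole ring rather than adding a single atom to it, so they set no scale for a methyl at this place. With compound 3 already at the lowest number shown, the author expects the step of a 1.5-fold higher number from compound 3 to compound 4 (0.18 log units; within the scatter) to stay within the scatter, in either direction. The estimate for compound 4 in this assay is therefore 3 nM, with a range from 0.7 nM to 12 nM.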

Compound 4, half-maximal effective concentration: 11 nM
Estimate against measurement, compound 4: 3.7-fold (0.56 log units) below, within the range that was stated.
By their numbers in this assay, from the lowest: compound 3; then compound 4; then compound 2; then compound 1.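

In this assay the added methyl alone produces a 5.5-fold higher number from compound 3 to compound 4 (0.74 log units; beyond the scatter) and so shows what the whole-ring swaps could not: this aromatic carbon, next to the ring nitrogen and next to the ring atom that bears a chloro group, responds to a single extra carbon atom. The change gives back only part of the ground held by the chlorinated ring, since an 11-fold lower number from compound 2 to compound 4 (1.06 log units; beyond the scatter) and a 42-fold lower number from compound 1 to compound 4 (1.63 log units; beyond the scatter) both remain large, although each is smaller than the matching step to compound 3. No independent data on these compounds say why the methyl raises the number.

The compounds shown leave open whether any group at this carbon raises the number or whether the step is specific to methyl, and an ethyl, a methoxy or an amine in the same place would help to separate those readings. Among these compounds, they also leave open whether methyl would produce a step of similar size on a ring without the chloro group, as the only methyl step here sits on the chlorinated ring.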